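Swapping the aryl group on a triazole: compound 2 to compound 3

A few compounds are considered here, and "the series" means these few. Any claim that something is new, unique, unknown or untested is made for them only; others in the source may bear on it.

Measured so far:
- compound 1, `Cc1ccc(-n2nncc2CN2C(=O)C3(C(C#N)=C(N)Oc4c3c3nc5ccccc5nc3c3ccccc43)c3ccccc32)c(C)c1`: > 50000 nM
- compound 2, `Cc1cccc(-n2nncc2CN2C(=O)C3(C(C#N)=C(N)Oc4c(N)cc5nc6ccccc6nc5c43)c3ccccc32)c1`: 12300 nM

Of the compounds shown here, two have been tested in a functional assay on A549 cells (Homo sapiens) for antiproliferative activity, read by MTT assay, with a stated time of 48 h; a higher number here means a weaker inhibitor, a lower number a stronger inhibitor. For compound 1 the value > 50000 nM is a limit of the assay, not a number. It sits at the limit of > 50000 nM in this assay, at which 1 of the 2 values shown sits. Among the compounds with values here, compound 2 is therefore the only compound with an actual number in this assay, where compound 2 gives 12300 nM, a weak result. Compound 1 and compound 2 differ in more than one place, so their two values say nothing about any single change.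

Compound 3, `CCc1cccc(C)c1-n1nncc1CN1C(=O)C2(C(C#N)=C(N)Oc3c(N)cc4nc5ccccc5nc4c32)c2ccccc21`, has not yet been measured. It differs from compound 2 in one place: 2-ethyl-6-methylphenyl in place of 3-methylphenyl on an aromatic nitrogen. Within the data shown here, no measured pair shows what such a change does here, so the expected step from compound 2 to compound 3 in this assay is a 1.2-fold higher number from compound 2 to compound 3 (0.09 log units; within the scatter), which is taken to be no more than the usual scatter. Compound 3 is thus expected to give about 15000 nM in this assay, with a likely range from 5000 nM to 50000 nM.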

Compound 3, half-maximal inhibitory concentration: > 50000 nM
Compound 3: a limit, no number; the forecaster's own chance of this, stated with the estimate: 20%; at least 3.3-fold (0.52 log units) between middle value and limit.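

Swapping 3-methylphenyl for 2-ethyl-6-methylphenyl on the aromatic nitrogen gives an at least 4.0-fold higher number from compound 2 to compound 3 (0.60 log units; beyond the scatter) in this assay, the first step in this set that can be tied to a single change, and it shows that activity in this assay does respond to the aryl group at this position. This step lies beyond the usual scatter, so the larger group on this nitrogen goes with a weaker result here, at least for this one pair. Compound 3 gives only a limit of the assay, not a number, so the true size of the step stays unknown, and the same ceiling already holds more than one compound: the limit of > 50000 nM in this assay, at which 2 of the 3 values shown sit.

The 2-ethyl-6-methylphenyl group differs from 3-methylphenyl in more than one feature, so this pair cannot tell whether the ethyl group, the placement of the methyl group or both go with the weaker result. From the compounds shown here alone, it also remains open how this position would respond to an unsubstituted phenyl, or to a phenyl carrying an amine or a carboxylic acid.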